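Aryl swap at the fused core: cytotoxicity notes

The source may hold more compounds than are shown below. What is called first, only, known or untested is meant among the compounds shown, and "the series" means these compounds.

Compound 1 `O=[N+]([O-])c1c(CS(=O)(=O)c2ccccc2)nc2c(-c3ccccc3)cc(Cl)cn12`, compound 2 `CCN(CC)c1ccc(-c2cc(Cl)cn3c([N+](=O)[O-])c(CS(=O)(=O)c4ccccc4)nc23)cc1` and compound 3 `O=[N+]([O-])c1c(CS(=O)(=O)c2ccccc2)nc2c(-c3ccc(CO)cc3)cc(Cl)cn12` share one core and differ only in the aryl group. In an ADME assay on HepG2 cells (Homo sapiens) for cytotoxicity, read by MTT assay, with a stated time of 72 h (on this read-out higher numbers stand for lower toxicity in this test and lower numbers for higher toxicity in this test), compound 1 returns only a limit, > 15600 nM. Compound 2 likewise gives only a limit in this assay, > 15600 nM. Going by the values given here, compound 3 is the sole member with a number in this assay, 13100 nM, while the other two sit at the limit of > 15600 nM in this assay, at which 2 of the 3 values shown sit. The steps of an at least 1.1-fold lower number from compound 1 to compound 3 (0.07 log units; that floor lies within the scatter) and an at least 1.1-fold lower number from compound 2 to compound 3 (0.07 log units; that floor lies within the scatter) are floors within the scatter, and a step that the two limits leave unreadable from compound 1 to compound 2 cannot be read. Compound 4 `O=[N+]([O-])c1c(CS(=O)(=O)c2ccccc2)nc2c(-c3cccnc3)cc(Cl)cn12` carries pyridin-3-yl in place of 4-(hydroxymethyl)phenyl on an aromatic carbon. Among the compounds with values here, no measured step covers this change; the neighbours show little movement. Compound 4 is expected near 14000 nM (range 7000 nM to 30000 nM), a step of a 1.1-fold higher number from compound 3 to compound 4 (0.03 log units; within the scatter) expected to stay within the scatter.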

Compound 4, half-maximal cytotoxic concentration: > 31300 nM
Compound 4: only a limit was reported; the forecaster's own chance of this, stated with the estimate: 50%; at least 2.2-fold (0.34 log units) between middle value and limit.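

Going by these compounds alone, at this position on the shared core, the change to pyridin-3-yl gives the only step in this assay that reads beyond the scatter: an at least 2.3-fold higher number from compound 3 to compound 4 (0.37 log units; beyond the scatter). Compound 4 is reported only as a limit: the limit of > 31300 nM in this assay, at which 1 of the 4 values shown sits. The steps from compound 1 and from compound 2 to compound 4 cannot be read.

On these data alone, whether the step follows the nitrogen of pyridin-3-yl or the loss of hydroxymethyl remains open. A pyridin-3-yl carrying hydroxymethyl, or a phenyl carrying a carboxylic acid, would help separate these.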